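This account rests on a few compounds, and the source may have more. Where it says the series, first, only, none or still open, it means among the compounds named here.

Three compounds with a shared core, differing only in the group on an aromatic nitrogen, have been tested in a functional assay on HT-29 cells (Homo sapiens) for inhibition, read by CCK-8 assay, with a stated time of 24 h; on this read-out higher numbers stand for weaker inhibition and lower numbers for stronger inhibition. Compound 1 `Cc1ccccc1-n1cc(-c2ccc(/C=C3\C(=O)Nc4ccccc43)cc2)nn1`, with 2-methylphenyl, gives 8710 nM. Compound 3 `O=C1Nc2ccccc2/C1=C/c1ccc(-c2cn(-c3ccc(Cl)cc3)nn2)cc1`, with 4-chlorophenyl, gives 14000 nM. The gap between these two is small, a 1.6-fold higher number from compound 1 to compound 3 (0.21 log units; within the scatter), so they cannot be told apart. Compound 2 `O=C1Nc2ccccc2/C1=C/c1ccc(-c2cn(-c3cccc(F)c3)nn2)cc1`, with 3-fluorophenyl, is reported only as a limit, > 20000 nM.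

Compound 4 `N#Cc1cccc(-n2cc(-c3ccc(/C=C4\C(=O)Nc5ccccc54)cc3)nn2)c1` takes compound 3 and puts 3-cyanophenyl in place of 4-chlorophenyl on an aromatic nitrogen. Among the measured compounds shown here, no measured compound carries this group, so the nearest guide is compound 2, whose group has its substituent named at the same ring number. Two steps involve compound 2: an at least 2.2-fold higher number from compound 1 to compound 2 (0.36 log units; beyond the scatter), and an at least 1.4-fold lower number from compound 2 to compound 3 (0.15 log units; that floor lies within the scatter). Together they hint that compound 4 could sit at a somewhat higher number than compound 3, though the second step does not separate the two compounds it joins. The expected change is small and towards a higher number, estimated as a 1.3-fold higher number from compound 3 to compound 4 (0.11 log units; within the scatter). A result reported only as a limit would also be no surprise. For compound 4 the estimated value is 18000 nM, with an expected range of 9000 nM to 36000 nM.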

Compound 4, half-maximal inhibitory concentration: > 20000 nM
Compound 4: no number, only a limit; the forecaster's own chance of this, stated with the estimate: 45%; middle value at least 1.1-fold (0.04 log units) from the limit.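

In this assay compound 4 gives > 20000 nM, which is a limit and not a number. Measured against the 2-methylphenyl group, 3-cyanophenyl on this aromatic nitrogen gives an at least 2.2-fold higher number from compound 1 to compound 4 (0.36 log units; beyond the scatter), a clear loss of inhibition, whereas measured against 4-chlorophenyl it gives an at least 1.4-fold higher number from compound 3 to compound 4 (0.15 log units; that floor lies within the scatter), so compound 3 and compound 4 are not firmly separated. A second group with its substituent named at the same ring number now ends at the limit, which makes 3-fluorophenyl and 3-cyanophenyl look alike in this test, although the step from compound 2 to compound 4 cannot be read and this resemblance rests on those two compounds alone: the limit of > 20000 nM in this assay, at which 2 of the 4 values shown sit.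

Going by these compounds, how far compound 2 and compound 4 lie past the limit stays open, so fluoro and cyano cannot be ranked against each other. Also open, on these data alone, is whether a 3-methylphenyl group, which would test the methyl of compound 1 at this other ring number, or a 3-aminophenyl group would bring the result back within the measurable range.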